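A few compounds are considered here, and "the series" means these few. Any claim that something is new, unique, unknown or untested is made for them only; others in the source may bear on it.

Compound 1 `Cc1cccc(Cc2cnc(CCc3ccc(-c4ccccc4C(=O)O)cc3)[nH]2)c1` gives 4310 nM in an in vitro functional assay on cells for agonist activity at Bombesin receptor subtype-3 (Homo sapiens), read by luminescence and calcium flux; on this read-out higher numbers stand for an effect only at larger amounts of compound and lower numbers for an effect already at smaller amounts. Compound 2 `O=C(O)c1ccccc1-c1ccc(CCc2ncc(-c3ccccc3)[nH]2)cc1` gives 4950 nM in this assay. Compound 3 `Cc1ccc(Cc2cnc(CCc3ccc(-c4ccccc4C(=O)O)cc3)[nH]2)cc1` gives 2660 nM in this assay.

Among these three, compound 3 carries the lowest number, though its steps to the others, a 1.6-fold lower number from compound 1 to compound 3 (0.21 log units; within the scatter) and a 1.9-fold lower number from compound 2 to compound 3 (0.27 log units; within the scatter), both stay within the scatter, so no order among them can be claimed. Compound 4 `O=C(O)c1ccccc1-c1ccc(CCc2ncc(Cc3cccc(Cl)c3)[nH]2)cc1` differs from compound 3 by 3-chlorophenyl in place of 4-methylphenyl on a saturated chain carbon bound to an aromatic carbon. The two steps that touch this same position, a 1.6-fold lower number from compound 1 to compound 3 (0.21 log units; within the scatter) and a 1.9-fold lower number from compound 2 to compound 3 (0.27 log units; within the scatter), were both small, so a further change at this position is expected to leave this assay essentially unchanged, with no step beyond the scatter. For compound 4 the expected value is 3000 nM, in the range 1200 nM to 7500 nM, an expected step of a 1.1-fold higher number from compound 3 to compound 4 (0.05 log units; within the scatter).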

Compound 4, half-maximal effective concentration: 825 nM
Compound 4: middle estimate off by 3.6-fold (0.56 log units), on the high side; the measured number lies below the stated range.
By their numbers in this assay, from the lowest: compound 4; then compounds 3, 1 and 2 (each within the scatter of the next).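

Until now, changes at this position in this assay had stayed within the scatter, but 3-chlorobenzyl goes beyond it, with a 3.2-fold lower number from compound 3 to compound 4 (0.51 log units; beyond the scatter) and a 6.0-fold lower number from compound 2 to compound 4 (0.78 log units; beyond the scatter) in the same direction. The closest comparison is chloro in place of methyl on an aromatic carbon, which alone gives a 5.2-fold lower number from compound 1 to compound 4 (0.72 log units; beyond the scatter) and is thus enough to set these two compounds apart. Nothing available here accounts for this shift. Still open, as far as these compounds go, is whether the lower number is particular to chloro, or whether bromo, methoxy or an amine on that aromatic carbon would match it. Also open, from the compounds shown here alone, is how 4-chlorobenzyl would compare with 3-chlorobenzyl.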